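Adding a cyano group on two different cores

The source may report more compounds than this note shows. Statements on the series, on what has been measured and on what is new or still open speak of the compounds shown alone.

Measured so far:
Compound 1 `CN(CCN(C)C(=O)n1cccn1)Cc1cccc(OCc2ccccc2)c1`: in an assay on membranes from brain for binding affinity to neutral cholesterol ester hydrolase 1 (Mus musculus), read by fluorescence, with stated times of 1 h and 30 min (a lower number here means a stronger inhibitor, a higher number a weaker inhibitor), compound 1 gives a limit, > 100000 nM.
Compound 2 `CN(CCN(C)C(=O)n1cc(C#N)cn1)Cc1cccc(OCc2ccccc2)c1`: in this assay compound 2 gives a limit, > 100000 nM.
Compound 3 `O=C(N1CCN(C(c2ccc3ccccc3c2)c2ccc3ccccc3c2)CC1)n1cccn1`: in this assay compound 3 gives a limit, > 100000 nM.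

Compound 1 and compound 2 differ in one place, (cyano in place of hydrogen on an aromatic carbon). The size of this step, a step that the two limits leave unreadable from compound 1 to compound 2, cannot be read because of the limit of > 100000 nM in this assay, at which 3 of the 3 values shown sit. Compound 4 `N#Cc1cnn(C(=O)N2CCN(C(c3ccc4ccccc4c3)c3ccc4ccccc4c3)CC2)c1` has not yet been measured; it carries the same change relative to compound 3, (cyano in place of hydrogen on an aromatic carbon). How the core of compound 1 differs from the core of compound 3 is not broken down here. Beside the earlier, unreadable step, the step from compound 3 to compound 4 in this assay is expected to be a number no higher from compound 3 to compound 4 (the limit leaves the size open), an expectation that rests on (the limit of > 100000 nM in this assay, at which 3 of the 3 values shown sit). Compound 4 is therefore estimated at about 100000 nM, within 30000 nM to 300000 nM, and most likely again reported only as a limit.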

Compound 4, half-maximal inhibitory concentration: > 100000 nM
Compound 4: a limit, no number; the forecaster's own chance of this, stated with the estimate: 80%; the middle value sits exactly at the limit.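

Compound 3 and compound 4 both give only a limit, not a number, so the step between them cannot be read: the limit of > 100000 nM in this assay, at which 4 of the 4 values shown sit.

As far as these compounds go, whether cyano in place of hydrogen changes inhibition on either core in this assay remains open.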